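The source may hold more compounds than are shown below. What is called first, only, known or untested is meant among the compounds shown, and "the series" means these compounds.

The measured compounds:
Compound 1, `CC1(C)Oc2ccc(Cc3ccccc3)cc2[C@@H](/N=C(\NC#N)Nc2ccc(Cl)cc2)[C@@H]1O`, gives 10000 nM in a functional assay (aorta) with Rattus norvegicus as the target; on this read-out lower numbers stand for stronger inhibition and higher numbers for weaker inhibition.
Compound 2, `C[C@@H]1CCC[C@H](C)N1S(=O)(=O)c1ccc2c(c1)[C@@H](/N=C(\NC#N)Nc1ccc(Cl)cc1)[C@H](O)C(C)(C)O2`, gives 500 nM in this assay.

Going by the values given here, compound 2 has the lower of the two numbers, and compound 1 is its only neighbour. Among the compounds with values here, the single step measured so far, a 20-fold lower number from compound 1 to compound 2 (1.30 log units; beyond the scatter), came from putting a (2,6-dimethylpiperidin-1-yl)sulfonyl group in place of a benzyl group on an aromatic carbon. Compound 3, `CC1CC(C)CN(S(=O)(=O)c2ccc3c(c2)[C@@H](/N=C(\NC#N)Nc2ccc(Cl)cc2)[C@H](O)C(C)(C)O3)C1`, keeps the sulfonyl group and differs from compound 2 in one place: 3,5-dimethylpiperidin-1-yl in place of 2,6-dimethylpiperidin-1-yl on a sulfonyl sulfur. The step from compound 1 to compound 2 touches the same part of the molecule but is a different kind of change, so it offers no direct guide to shifting the two methyl groups around the piperidine ring. Within the data shown here, with no comparable step, no change beyond the scatter is expected, and the step estimated here is a 1.4-fold higher number from compound 2 to compound 3 (0.15 log units; within the scatter). Compound 3 is therefore expected to give about 700 nM in this assay, within a range from 200 nM to 3000 nM.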

Compound 3, half-maximal inhibitory concentration: 32100 nM
Beside the measured number, compound 3's estimate is 46-fold (1.66 log units) below it, outside the stated range (above it).
By their numbers in this assay, from the lowest: compound 2; then compound 1; then compound 3.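

In this assay, the two dimethylpiperidine groups have the same atoms, yet 3,5-dimethylpiperidin-1-yl in place of 2,6-dimethylpiperidin-1-yl gives a 64-fold higher number from compound 2 to compound 3 (1.81 log units; beyond the scatter), so the sulfonyl link alone does not secure the lower number and the placing of the methyl groups on the ring matters greatly. Going by these compounds alone, replacing benzyl can also go either way: the sulfonyl group of compound 2 lowered the number, whereas the one in compound 3 gives a 3.2-fold higher number from compound 1 to compound 3 (0.51 log units; beyond the scatter), a modest move in the opposite direction. No measurement is available to explain why the two groups differ.

The 2,6-dimethylpiperidin-1-yl group has defined stereocentres and the 3,5-dimethylpiperidin-1-yl group has none, so the role of methyl placement cannot be separated from that of stereochemistry. As far as these compounds go, it also remains open where a piperidin-1-yl group without methyl groups, or a morpholin-4-yl group, would fall.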